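Series notes: HepG2 toxicity, pyridinyl to pyrimidinyl amide

This account rests on a few compounds, and the source may have more. Where it says the series, first, only, none or still open, it means among the compounds named here.

Measured in a toxicity assay on HepG2 cells (Homo sapiens) for inhibition, read by CellTiter-Glo, with a stated time of 48 h (on this read-out lower numbers stand for stronger inhibition and higher numbers for weaker inhibition), so far:
Compound 1 `COc1ccc2nc(C)cc(OCC(=O)Nc3cc(C)ccc3OC)c2c1` gives > 100000 nM, a limit of the assay.
Compound 2 `COc1ccc2nc(C)cc(OCC(=O)Nc3ccncc3)c2c1` gives > 100000 nM, a limit of the assay.

Compound 2 stands at the limit of this assay, where both shown values sit (the limit of > 100000 nM in this assay, at which 2 of the 2 values shown sit). Going by the values given here, the single measured step, a step that the two limits leave unreadable from compound 1 to compound 2, is unreadable between the two limits. Compound 3 `COc1ccc2nc(C)cc(OCC(=O)Nc3ccncn3)c2c1` differs from compound 2 by pyrimidin-4-yl in place of pyridin-4-yl on an amide-type nitrogen. Among the compounds with values here, no measured step bears readably on this change, so the data give no direction. The step that the limit leaves unreadable from compound 2 to compound 3 is expected to be none beyond the scatter. Compound 3 is therefore estimated in this assay at 200000 nM, range 80000 nM to 500000 nM, most likely again reported only as a limit.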

Compound 3, half-maximal inhibitory concentration: > 100000 nM
Compound 3 was reported as a limit; the forecaster's own chance of this, stated with the estimate: 85%; the middle value is on the limit's open side.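

Going by these compounds alone, compound 1, compound 2 and compound 3 all sit at a limit of the assay, so no step among them can be read. The compounds shown leave open what in this assay would give a value inside the measurable range.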